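This account rests on a few compounds, and the source may have more. Where it says the series, first, only, none or still open, it means among the compounds named here.

Measured compounds in a functional assay on SK-BR-3 cells (Homo sapiens) for antiproliferative activity, read by MTT assay, with a stated time of 72 h; a higher number here means a weaker inhibitor, a lower number a stronger inhibitor:
Compound 1 `CCN1CCN(c2cc(C)c3cc(NC(=O)c4cccnc4)ccc3n2)CC1`, for which compound 1 gives 10600 nM.
Compound 2 `CCNc1cc(C)c2cc(NC(=O)c3ccc(Cl)c(Cl)c3)ccc2n1`, for which compound 2 gives 28200 nM.
Compound 3 `Cc1cc(N2CCN(C)CC2)nc2ccc(NC(=O)c3ccc(Cl)c(Cl)c3)cc12`, for which compound 3 gives 6320 nM.

Among these three numbers compound 1 stands second highest. Its nearest neighbour is compound 3, which lies within the scatter of compound 1, so the two cannot be ordered; compound 2 gives a higher number than compound 1, and that gap lies beyond the scatter.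

The unmeasured compound 4 `CCN1CCN(c2cc(C)c3cc(NC(=O)c4cccc(Br)c4)ccc3n2)CC1` is reached from compound 1 by a single change on the carbonyl carbon of the amide: 3-bromophenyl in place of pyridin-3-yl on a carbonyl carbon. Within the data shown here, the only step measured so far, a 4.5-fold lower number from compound 2 to compound 3 (0.65 log units; beyond the scatter), concerns the amine on the aromatic carbon and leaves the aryl amide untouched, so it does not speak to this change. Compounds 1 and 3 do differ in their aryl amides, among other things, but their values lie within the scatter of each other, which gives no sign that the aryl amide moves the number much. The expectation for this assay is therefore no step beyond the scatter, and the step of a 1.3-fold lower number from compound 1 to compound 4 (0.12 log units; within the scatter) is estimated accordingly. Compound 4 is estimated at 8000 nM, within a range from 3000 nM to 25000 nM.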

Compound 4, half-maximal inhibitory concentration: 13300 nM
The estimate for compound 4 lay 1.7-fold (0.22 log units) below the measured number, within the range that was stated.
By their numbers in this assay, from the lowest: compounds 3, 1 and 4 (each within the scatter of the next, the first and the last beyond it); then compound 2.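

In this assay, putting 3-bromophenyl in place of pyridin-3-yl on the carbonyl carbon gives a 1.3-fold higher number from compound 1 to compound 4 (0.10 log units; within the scatter). Among these compounds, this is the first reading of this position with the rest of the molecule held fixed, as the earlier compounds held no pair differing only here, and it shows that this exchange of a ring with one nitrogen for a carbon-only ring bearing a bromine does not separate the two compounds. No measured evidence bears on why these two groups read alike.

Going by these compounds, whether a different kind of group on this carbonyl carbon, such as an aliphatic amine, a carboxylic acid or a longer alkyl chain in place of the aromatic ring, would give a step beyond the scatter remains open. On these data alone, it is also open whether the amine exchange seen in a 4.5-fold lower number from compound 2 to compound 3 (0.65 log units; beyond the scatter), read with a different aryl amide, would carry over to compounds bearing pyridin-3-yl or 3-bromophenyl on the carbonyl carbon.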